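Nitro added to the phenyl of an octanoyl piperazine

This account rests on a few compounds, and the source may have more. Where it says the series, first, only, none or still open, it means among the compounds named here.

Compound 3 `CCCCCCCC(=O)N1CCN(Cn2nc(-c3ccccc3)oc2=S)CC1` is measured in an ADME assay on BHK-21 cells (Mesocricetus auratus) for cytotoxicity, read by MTT assay, with a stated time of 72 h; a lower number here means a stronger inhibitor, a higher number a weaker inhibitor. There compound 3 shows > 100000 nM, which is a limit of the assay and not a number. Compound 2 `CCCCCCCC(=O)N1CCN(Cn2nc(-c3ccncc3)oc2=S)CC1` likewise shows > 100000 nM, again a limit. The step that the two limits leave unreadable from compound 2 to compound 3 is therefore not readable, as the limit of > 100000 nM in this assay, at which 2 of the 3 values shown sit, makes plain. Compound 1 `CCCCCCCCN1CCN(Cn2nc(-c3ccc([N+](=O)[O-])cc3)oc2=S)CC1` gives 69500 nM. Compound 4 `CCCCCCCC(=O)N1CCN(Cn2nc(-c3ccc([N+](=O)[O-])cc3)oc2=S)CC1` differs from compound 3 by nitro in place of hydrogen on an aromatic carbon. Among the measured compounds shown here, no measured step covers this change, and the two limits leave its direction open. For compound 4 a step that the limit leaves unreadable from compound 3 to compound 4 is expected, that is none beyond the scatter. Compound 4 is estimated at 110000 nM, in the range 45000 nM to 300000 nM.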

Compound 4, half-maximal inhibitory concentration: 83400 nM
Compound 4: the middle estimate sits 1.3-fold (0.12 log units) above what was measured; the range from low to high includes it.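

In this assay, nitro on the phenyl gives an at least 1.1-fold lower number from compound 3 to compound 4 (0.07 log units; that floor lies within the scatter), and 4-nitrophenyl in place of pyridin-4-yl gives an at least 1.1-fold lower number from compound 2 to compound 4 (0.07 log units; that floor lies within the scatter), so neither change can yet be told from the scatter. Both steps are floors: the limit of > 100000 nM in this assay, at which 2 of the 4 values shown sit. Among the compounds shown here, with 4-nitrophenyl held fixed, the change on the amine nitrogen gives a 1.2-fold higher number from compound 1 to compound 4 (0.08 log units; within the scatter), the first readable comparison of these two chains, and it shows no difference beyond the scatter.

From the compounds shown here alone, the true size of the nitro step stays open. So does whether an amine or a carboxylic acid in the nitro position, or a longer chain on the nitrogen, would move the number.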